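The compounds below may be only part of what the source reports. "The series", "measured", "known", "first", "only" and "open" are said of these compounds alone.

Of the compounds shown here, two have been measured in a functional assay on HCT-116 cells (Homo sapiens) for inhibition, read by sulforhodamine B assay, with a stated time of 48 h; on this read-out lower numbers stand for higher toxicity in this test and higher numbers for lower toxicity in this test. Compound 1 `COc1cc2cc(Oc3ccc(NC(=O)Nc4cccc(C(F)(F)F)c4)cc3)c(C)nc2cc1OC` gives 20400 nM and compound 2 `COc1cc2cc(Oc3ccc(NC(=O)Nc4ccc(Cl)c(C(F)(F)F)c4)cc3)c(C)nc2cc1OC` gives 14000 nM. The step of a 1.5-fold lower number from compound 1 to compound 2 (0.16 log units; within the scatter) stays within the scatter, so compound 2 holds the lower of the two numbers without any separation from compound 1 that can be read as a real difference.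

Compound 3 `COc1cc2cc(Oc3ccc(NC(=O)Nc4ccc(Cl)c(Cl)c4)cc3)c(C)nc2cc1OC` is the next member. Its change from compound 2 is chloro in place of trifluoromethyl on an aromatic carbon. Within the data shown here, no measured step removes a trifluoromethyl group, and the only step recorded, a 1.5-fold lower number from compound 1 to compound 2 (0.16 log units; within the scatter), was itself within the scatter. Among the measured compounds shown here, the two values so far sit close together, and nothing among them points to a direction for this exchange on the ring. The expectation for compound 3 is therefore a step of a 1.1-fold higher number from compound 2 to compound 3 (0.06 log units; within the scatter) in this assay that does not move beyond the scatter. Compound 3 is estimated at 16000 nM in this assay, with a range from 6000 nM to 45000 nM, the width of that range reflecting the absence of any measured precedent for the change.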

Compound 3, concentration lethal to 50% of the cells: 32600 nM
Compound 3: the middle estimate sits 2.0-fold (0.31 log units) below what was measured, within the range that was stated.
By their numbers in this assay, from the lowest: compounds 2, 1 and 3 (each within the scatter of the next, the first and the last beyond it).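

In this assay, among these compounds, trifluoromethyl leaving for chloro on the aromatic carbon ortho to a chloro group gives a 2.3-fold higher number from compound 2 to compound 3 (0.37 log units; beyond the scatter) and so provides the first step beyond the scatter, modest in size and in the direction of lower toxicity in this test. This position therefore registers the exchange of one group for the other, whereas the addition of chloro in the earlier step stayed within the scatter, although the reading rests on a single pair. The wider change gives a 1.6-fold higher number from compound 1 to compound 3 (0.20 log units; within the scatter) and stays within the scatter, so 3,4-dichlorophenyl cannot be separated from 3-(trifluoromethyl)phenyl on the amide-type nitrogen, and the gain from the exchange does not carry over to that comparison.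

From the compounds shown here alone, whether the same step would appear on a ring without the chloro group remains open, as does the reading in this assay of a nitrile, a methoxy or a dimethylamino group at this place. No measurement available for these compounds bears on why the step arises.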